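Compound 3: one more chain extension

The source may report more compounds than this note shows. Statements on the series, on what has been measured and on what is new or still open speak of the compounds shown alone.

In a functional assay, with a stated time of 30 min (on this read-out lower numbers stand for stronger inhibition and higher numbers for weaker inhibition), compound 1 (`CCCCOc1cc(OC)c(Br)cc1C(C)=O`) gives 42300000 nM and compound 2 (`CCCCCCCCOc1cc(OC)c(Br)cc1C(C)=O`) gives 39000000 nM on the same read-out, so compound 2 stands level with compound 1 within the scatter. Compound 3 (`CCCCCCCCCCCCCCCCOc1cc(OC)c(Br)cc1C(C)=O`) differs from compound 2 by one change: octyl in place of hydrogen on a saturated chain carbon, eight bonds along the chain from an oxygen on an aromatic ring. For the measured compounds named here, the single measured step bearing on it is butyl in place of hydrogen, four bonds along the chain from an oxygen on an aromatic ring: a 1.1-fold lower number from compound 1 to compound 2 (0.04 log units; within the scatter) and this stays within the scatter. Going by the values given here, no measurement yet covers a chain of the length in compound 3, so the range is kept wide. An expected step of a 1.1-fold lower number from compound 2 to compound 3 (0.02 log units; within the scatter) means no change beyond the scatter and no firm direction. For compound 3 the estimated value is 37000000 nM (expected range 15000000 nM to 90000000 nM).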

Compound 3, half-maximal inhibitory concentration: 6500000 nM
Beside the measured number, compound 3's estimate is 5.7-fold (0.76 log units) above it; the whole stated range lies above it.
By their numbers in this assay, from the lowest: compound 3; then compounds 2 and 1 (each within the scatter of the next).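

In this assay this position is no longer flat: octyl in place of hydrogen, eight bonds along the chain from an oxygen on an aromatic ring, gives a 6.0-fold lower number from compound 2 to compound 3 (0.78 log units; beyond the scatter) and so moves the number beyond the scatter. The earlier butyl change gave only a 1.1-fold lower number from compound 1 to compound 2 (0.04 log units; within the scatter) and stayed within the scatter, so across compound 1, compound 2 and compound 3 the number does not fall evenly with each extension, and a flat first step did not predict the second. Nothing measured here accounts for the step from octyl.

For the compounds shown here, whether a chain longer than the one in compound 3 lowers the number further, or the number levels off or rises again, remains open. Going by these compounds, it is also open whether an amine or a carboxylic acid in place of octyl would give a step of this size.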